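The source may report more compounds than this note shows. Statements on the series, on what has been measured and on what is new or still open speak of the compounds shown alone.

Going by the values given here, in an ADME assay on Vero cells (Chlorocebus sabaeus) for cytotoxicity, read by MTT assay, with a stated time of 72 h (a higher number here means that more compound is needed for the effect, a lower number that less compound is needed), compound 1 (`COc1cccc(C(=O)Nc2nc(-c3ccccn3)cs2)c1`) gives 2800 nM and this is the only number available so far. Compound 2 (`O=C(Nc1nc(-c2ccccn2)cs1)c1ccccc1O`) has no such number: its entry reads "not determined" (no result reported) in this assay so it cannot be ranked against compound 1. Compound 3 (`O=C(Nc1nc(-c2ccccn2)cs1)c1cccc(Br)c1`) has yet to be measured in this assay and is the next structure to follow. The structural change is 3-bromophenyl in place of 2-hydroxyphenyl on a carbonyl carbon and the rest of the molecule stays the same. Among the compounds with values here, with no starting value, the size of this step cannot be read from the data, and no measured step exists to serve as a guide. The nearest reference is compound 1 at 2800 nM which differs from compound 3 only in the group on that carbonyl carbon, so no shift beyond the usual scatter is expected, in either direction. For compound 3 the estimated value is 3000 nM with an expected range from 900 nM to 10000 nM and this wide span reflects how few data exist so far.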

Compound 3, half-maximal effective concentration: 16100 nM
For compound 3 the middle estimate is 5.4-fold (0.73 log units) below the measured one; the measured number lies above the stated range.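

In this assay, going by these compounds alone, the exchange of methoxy for bromo on an aromatic carbon gives a 5.8-fold higher number from compound 1 to compound 3 (0.76 log units; beyond the scatter) and this is the first measured step. It shows that the number responds to the group on this aromatic ring even with the rest of the molecule unchanged: more of the bromo compound is needed to reach the effect, and compound 2 offers no comparison since it has no value, so any step involving it cannot be read. No measurement at hand explains why bromo and methoxy differ in this way.

As far as these compounds go, a single step between two compounds sets no trend, so it remains open whether the higher number belongs to bromo in particular or would also appear with chloro, fluoro or trifluoromethyl in the same place. From the compounds shown here alone, how an amine or a carboxylic acid on this ring would compare also stays unknown, as does the effect of any change made to the shared core instead of to this ring.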